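Notes on the amine aryl change toward compound 4

A few compounds are considered here, and "the series" means these few. Any claim that something is new, unique, unknown or untested is made for them only; others in the source may bear on it.

Measured so far, in a functional assay on HL-60 cells (Homo sapiens) for cytotoxicity, read by MTT assay, with a stated time of 48 h; on this read-out lower numbers stand for stronger inhibition and higher numbers for weaker inhibition:
compound 1 `Fc1cccc(-c2nc(Nc3ccccc3)c3cc(F)ccc3n2)c1` gives 48300 nM.
compound 2 `Fc1ccc(Nc2nc(-c3cccc(F)c3)nc3ccc(F)cc23)cc1` gives only a limit of the assay, > 50000 nM.
compound 3 `Fc1cccc(-c2nc(Nc3cccc(Cl)c3)c3cc(F)ccc3n2)c1` gives only a limit of the assay, > 50000 nM.

Compound 2 stands at the limit of this assay, so its number is not read; the limit of > 50000 nM in this assay, at which 2 of the 3 values shown sit, holds for it. The step of an at least 1.0-fold higher number from compound 1 to compound 2 (0.01 log units; that floor lies within the scatter) and the step of an at least 1.0-fold higher number from compound 1 to compound 3 (0.01 log units; that floor lies within the scatter) are both floors whose size is not readable beyond the scatter, and the step that the two limits leave unreadable from compound 2 to compound 3 is left unreadable by the two limits. Compound 4 `Oc1ccccc1Nc1nc(-c2cccc(F)c2)nc2ccc(F)cc12` differs from compound 2 in one place: 2-hydroxyphenyl in place of 4-fluorophenyl on a nitrogen on an aromatic ring. Going by the values given here, the only measured step that changes the same aryl on the ring nitrogen is the one from compound 2 to compound 3, and it gives no readable size, so no direction can be drawn from the data; all three measured values sit at or close to the limit. Compound 4 is therefore expected to sit near the limit as well, with the expected step of a number no higher from compound 2 to compound 4 (the limit leaves the size open). The estimate for compound 4 in this assay is 50000 nM, within 20000 nM to 120000 nM.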

Compound 4, half-maximal inhibitory concentration: 44400 nM
Estimate against measurement, compound 4: 1.1-fold (0.05 log units) above; the measured number falls inside the stated range.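

In this assay, going by these compounds alone, the 2-hydroxyphenyl on the nitrogen gives the only read number for a substituted aryl at this place, with compound 4 at 44400 nM on the shared core. The change still carries no size beyond the scatter (an at least 1.1-fold lower number from compound 2 to compound 4 (0.05 log units; that floor lies within the scatter)) (an at least 1.1-fold lower number from compound 3 to compound 4 (0.05 log units; that floor lies within the scatter)), and the hydroxy in place of hydrogen leaves compound 4 level with the unsubstituted phenyl of compound 1 (a 1.1-fold lower number from compound 1 to compound 4 (0.04 log units; within the scatter)). Compound 2 and compound 3 remain limits of the assay, so how far the hydroxy change reaches from them cannot be read: the limit of > 50000 nM in this assay, at which 2 of the 4 values shown sit.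

Left open is whether any aryl on this nitrogen gives a number clearly apart from those near the limit. Also open, on these data alone, is whether an amine or a carboxylic acid in place of the hydroxy would read differently.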